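From 4-fluorobenzyl to 4-methylphenyl on a sulfur

The source may hold more compounds than are shown below. What is called first, only, known or untested is meant among the compounds shown, and "the series" means these compounds.

In a functional assay on DU-145 cells (Homo sapiens) for inhibition, read by trypan blue exclusion, with a stated time of 96 h (a higher number here means a weaker inhibitor of growth, a lower number a stronger inhibitor of growth), compound 1 (`Cc1cc(C)cc(/C=C(/SCc2ccc(F)cc2)C(=O)c2ccc(Br)cc2)c1`) gives 10000 nM and compound 2 (`Cc1ccc(S/C(=C/c2c[nH]c3ccccc23)C(=O)c2ccc(Br)cc2)cc1`) gives 10000 nM. Compound 3 (`O=C(/C(=C\c1c[nH]c2ccc(Cl)cc12)SCc1ccc(F)cc1)c1ccc(Br)cc1`) gives 1000 nM, the lowest number of the three and beyond the scatter from both others. Compound 4 (`Cc1ccc(S/C(=C/c2c[nH]c3ccc(Cl)cc23)C(=O)c2ccc(Br)cc2)cc1`) has 4-methylphenyl in place of 4-fluorobenzyl on a sulfur. For the measured compounds named here, no measured step covers this change. Going by the values given here, the only measured step, a 10-fold lower number from compound 1 to compound 3 (1.00 log units; beyond the scatter), concerns 5-chloro-1H-indol-3-yl in place of 3,5-dimethylphenyl, a change at another place, and compound 4 keeps the 5-chloro-1H-indol-3-yl of compound 3. Compound 2 carries 4-methylphenyl on a sulfur and stands at 10000 nM, but it lacks that chloro group, so it offers only a mild caution towards a higher number. The expected change is a 1.5-fold higher number from compound 3 to compound 4 (0.18 log units; within the scatter), which would not exceed the scatter, although the uncertainty is wide. For compound 4 the estimated value is 1500 nM, with an expected range of 300 nM to 7000 nM.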

Compound 4, concentration for 50% growth inhibition: 1000 nM
Compound 4: the middle estimate sits 1.5-fold (0.18 log units) above what was measured; low and high end bracket the measured number.
By their numbers in this assay, from the lowest: compounds 3 and 4 (each within the scatter of the next); then compounds 1 and 2 (each within the scatter of the next).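

In this assay, 4-methylphenyl in place of 4-fluorobenzyl on the sulfur gives no change at the digits printed from compound 3 to compound 4 (within the scatter), so with the 5-chloro-1H-indol-3-yl group present, these two sulfur substituents cannot be told apart. Chloro in place of hydrogen on an aromatic carbon gives a 10-fold lower number from compound 2 to compound 4 (1.00 log units; beyond the scatter), a step beyond the scatter that isolates the chloro group with the 4-methylphenyl on the sulfur held fixed. No measurement offered here accounts for either result.

The compounds shown leave open whether the sulfur accepts groups of another kind, such as a substituent bearing an amine or a carboxylic acid, or a longer chain in place of 4-fluorobenzyl. They also leave open whether the chloro step would be of similar size with 4-fluorobenzyl on the sulfur.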